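The source may report more compounds than this note shows. Statements on the series, on what has been measured and on what is new or still open speak of the compounds shown alone.

In a functional assay on SGC-7901 cells (Homo sapiens) for antiproliferative activity, read by MTT assay, with a stated time of 72 h (a higher number here means a weaker inhibitor, a lower number a stronger inhibitor), compound 3 `COc1cc(-n2cnc3ccc(-c4cc(F)ccc4F)cc32)cc(OC)c1OC` gives 6590 nM, the highest of the two numbers found so far, with compound 2 `COc1cc(-n2cnc3ccc(-c4ccc(C(F)(F)F)cc4)cc32)cc(OC)c1OC` at 890 nM as its nearest neighbour. Compound 1 `COc1cc(-c2ccc3ncn(-c4cc(OC)c(OC)c(OC)c4)c3c2)cc(OC)c1OC` gives > 10000 nM, which is a limit of the assay and not a number (the limit of > 10000 nM in this assay, at which 1 of the 3 values shown sits). Within the data shown here, the only measured step, a 7.4-fold higher number from compound 2 to compound 3 (0.87 log units; beyond the scatter), arose from 2,5-difluorophenyl in place of 4-(trifluoromethyl)phenyl and shows that the group on this ring changes the number markedly. Compound 4 `COc1cc(-n2cnc3ccc(-c4ccccc4)cc32)cc(OC)c1OC` differs from compound 3 by phenyl in place of 2,5-difluorophenyl on an aromatic carbon. Among the measured compounds shown here, no measured step strips fluorines from this ring, so the expectation is loose; since compound 2 with another group gave 890 nM, a modest downward move is expected, a 2.2-fold lower number from compound 3 to compound 4 (0.34 log units; beyond the scatter). Compound 4 is thus estimated at 3000 nM, between 800 nM and 12000 nM.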

Compound 4, half-maximal inhibitory concentration: 290 nM
Beside the measured number, compound 4's estimate is 10-fold (1.01 log units) above it; measured number below the stated range.
By their numbers in this assay, from the lowest: compound 4; then compound 2; then compound 3. At a limit, above all of these: compound 1.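

In this assay, the unsubstituted phenyl gives a lower number than either substituted ring: the loss of both fluorines brings a 23-fold lower number from compound 3 to compound 4 (1.36 log units; beyond the scatter), and hydrogen in place of trifluoromethyl brings a 3.1-fold lower number from compound 2 to compound 4 (0.49 log units; beyond the scatter). Neither substituent is therefore needed at this position, and each pattern shown here goes with a weaker result than the bare ring. Nothing measured here explains these differences. From the compounds shown here alone, whether an amine or a hydroxyl on this ring would match or improve on compound 4 remains open.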